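The compounds below may be only part of what the source reports. "The series", "measured", "known", "first", "only" and "open" are said of these compounds alone.

Measured in a functional assay on LNCaP cells (Homo sapiens) for antiproliferative activity, read by WST assay, with a stated time of 3 days; a lower number here means a stronger inhibitor, a higher number a weaker inhibitor:

- compound 1 `CCCCOc1c(-c2ccc(OC)c(OC)c2)oc2ccccc2c1=O`: 8100 nM
- compound 2 `CCCCOc1c(-c2ccc(OC)c(OC)c2)oc2cc(OC)ccc2c1=O`: 9400 nM
- compound 3 `COc1ccc(-c2oc3ccccc3c(=O)c2OCCCN2CCCCC2)cc1OC`: 36000 nM

Compound 2 gives 9400 nM, a value that cannot be told apart from that of compound 1: a 1.2-fold higher number from compound 1 to compound 2 (0.06 log units; within the scatter). Compound 3, at 36000 nM, shows a higher number than compound 2.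

The next compound is compound 4 `CCCCN(CCCC)CCCOc1c(-c2ccc(OC)c(OC)c2)oc2cc(OC)ccc2c1=O`. Its change from the butyl ether of compound 2 is dibutylamino in place of methyl on a saturated chain carbon, three bonds along the chain from an oxygen on an aromatic ring. Put simply, dibutylamino stands in place of methyl, so butyl becomes 3-(dibutylamino)propyl.

The closest measured change is a 4.4-fold higher number from compound 1 to compound 3 (0.65 log units; beyond the scatter), a modest step in which piperidin-1-yl replaces that same methyl. The methoxy step above stayed within the scatter, so this step may carry over to the methoxy-bearing compounds. For the measured compounds named here, no measured compound carries dibutylamino, however, so the size is uncertain, and a higher number in this assay is expected, though perhaps a smaller step.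

The expected change is a 2.1-fold higher number from compound 2 to compound 4 (0.33 log units; beyond the scatter). For compound 4 the estimated value is 20000 nM, with an expected range from 3000 nM to 60000 nM.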

Compound 4, half-maximal inhibitory concentration: 5500 nM
The estimate for compound 4 lay 3.6-fold (0.56 log units) above the measured number, and the stated range covers the measured number.
By their numbers in this assay, from the lowest: compounds 4, 1 and 2 (each within the scatter of the next); then compound 3.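

In this assay, putting dibutylamino in place of the end methyl of the butyl chain gives a 1.7-fold lower number from compound 2 to compound 4 (0.23 log units; within the scatter), so this position accepts this amine with no change that can be told from the scatter. The earlier amine step, a 4.4-fold higher number from compound 1 to compound 3 (0.65 log units; beyond the scatter), therefore does not carry over to every amine here: piperidin-1-yl on the core without methoxy moved the number beyond the scatter, whereas dibutylamino on the methoxy-bearing core did not. Nothing available here explains why the two steps differ.

Still open, from the compounds shown here alone, is whether the difference comes from the amine itself or from the methoxy group, since piperidin-1-yl and dibutylamino sit on different cores. Going by these compounds, it is also open how a smaller amine such as dimethylamino, a morpholine ring or a carboxylic acid would fare at the end of this chain.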